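The source may report more compounds than this note shows. Statements on the series, on what has been measured and on what is new or still open speak of the compounds shown alone.

Three compounds have been measured in a functional assay on the whole organism (artery, strain albino) with Rattus norvegicus as the target, with a stated time of 180 min, at a dose of 10 mg/kg by the oral route; a lower number here means less inhibition, a higher number more inhibition at the dose given (going by the name of the read-out):

Compound 1, `COc1ccc(C2N=C(SCc3ccccc3Cl)NC(C)=C2C(=O)Nc2ccc(Br)cc2)cc1`, gives 11.3%.
Compound 2, `COc1ccc(C2N=C(SCc3cccc(Cl)c3)NC(C)=C2C(=O)Nc2ccc(Br)cc2)cc1`, gives 27.3%.
Compound 3, `CC1=C(C(=O)Nc2ccc([N+](=O)[O-])cc2)C(c2cccc([N+](=O)[O-])c2)N=C(SCc2ccccc2Cl)N1`, gives 9.3%.

Compounds 1 and 2 share a core and differ in one place only: 3-chlorophenyl in place of 2-chlorophenyl on a saturated chain carbon bound to a sulfur. This change is accompanied by a step of a number 16 percentage points higher from compound 1 to compound 2 (beyond the scatter) in this assay. Compound 3 carries a different core; the difference between the core of compound 1 and the core of compound 3 is not broken down here, and the two values, compound 1 at 11.3% and compound 3 at 9.3%, lie within the scatter of each other, so nothing about order can be said between them.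

Compound 4, `CC1=C(C(=O)Nc2ccc([N+](=O)[O-])cc2)C(c2cccc([N+](=O)[O-])c2)N=C(SCc2cccc(Cl)c2)N1`, has not yet been measured. It stands to compound 3 exactly as compound 2 stands to compound 1: 3-chlorophenyl in place of 2-chlorophenyl on a saturated chain carbon bound to a sulfur. The place of the change is the same in both pairs, so this is the same change made on the other core.

Among the compounds with values here, the one earlier instance of this change gave the step of a number 16 percentage points higher from compound 1 to compound 2 (beyond the scatter). Resting on that single precedent and on the value of compound 3, 9.3%, the step from compound 3 to compound 4 is expected to be about a number 12.7 percentage points higher from compound 3 to compound 4 (beyond the scatter) in this assay. The change has been seen only once, on a different core. The expectation is held loosely. Compound 4 is therefore estimated at 22%, with a range from 8% to 38%.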

Compound 4, a percentage reported as inhibition, in the whole organism at one dose (the size of the read-out at that dose, not a potency): 14.9%
Beside the measured number, compound 4's estimate is 7.1 percentage points above it; low and high end bracket the measured number.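

In this assay, 3-chlorophenyl in place of 2-chlorophenyl on a saturated chain carbon bound to a sulfur gives, on the second core, a step of a number 5.6 percentage points higher from compound 3 to compound 4 (within the scatter). Set beside the earlier instance, the two steps cannot be told apart, so the data give no sign that the core alters the effect of this change: the same change on two cores in this assay, a number 16 percentage points higher (beyond the scatter) from compound 1 to compound 2 and a number 5.6 percentage points higher (within the scatter) from compound 3 to compound 4, 10.4 percentage points apart, within the scatter of two such steps

Within the data shown here, this does not show that the change carries over intact, since on the core of compound 3 the step by itself cannot be told from no step at all, and two pairs can neither establish a shared step nor rule out a smaller one on that core.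

The compounds shown leave open how the series reads with other groups in the same place, on a saturated chain carbon bound to a sulfur, such as an unsubstituted phenyl, a methoxyphenyl or a pyridine ring in place of the chlorophenyl. They also leave open which part of the difference between the two cores, if any, bears on the size of the step, and whether the picture holds at other doses or stated times.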